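The source may report more compounds than this note shows. Statements on the series, on what has been measured and on what is new or still open speak of the compounds shown alone.

Measured compounds in an assay on HEK293 cells for positive allosteric modulation of metabotropic glutamate receptor 5 (Rattus norvegicus); a lower number here means that less compound is needed, a higher number that more compound is needed for the effect:
- compound 1, `CSc1ncc(C#Cc2cccc(C)c2)cn1`: "not active" (no number reported)
- compound 2, `CNc1ncc(C#Cc2cccc(C)c2)cn1`: 21100 nM
- compound 3, `COc1ncc(C#Cc2ccccc2)cn1`: "not active" (no number reported)

Compound 3 stands at the bottom of what is known: in this assay compound 3 is reported only as "not active" (no number reported), with no half-maximal effective concentration given. Compound 1 shares that outcome, so two of the three measured compounds give no number at all, and only compound 2 gives a value, and a high one. No pair of measured compounds differs in a single place, so no step size can be read from the numbers shown; the series so far says only that a numbered result is rare and weak when it appears.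

Compound 4, `COc1ncc(C#Cc2cccc(C)c2)cn1`, is the next entry. It differs from compound 3 by methyl in place of hydrogen on an aromatic carbon. Compound 1 and compound 2 both carry that methyl already, and of those only compound 2 gives a number in this assay.

Among the compounds with values here, with no measured step to lean on, the expectation for compound 4 is at best a modest move in this assay, either none beyond the scatter or a weak number appearing where compound 3 had none. Compound 4 is estimated at 25000 nM, within 8000 nM to 80000 nM, with a real chance that again no number is reported.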

Compound 4, half-maximal effective concentration: "not active" (no number reported)
Compound 4: no number reported, so the estimate cannot be set against anything.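

In this assay compound 3 gives "not active" (no number reported) and compound 4 gives "not active" (no number reported), so no step can be read for methyl in place of hydrogen. No evidence on hand bears on this result. The compounds shown leave open whether that methyl shifts the half-maximal effective concentration at all in this assay.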